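The source may hold more compounds than are shown below. What is called first, only, known or untested is meant among the compounds shown, and "the series" means these compounds.

Measured so far in a functional assay on A549 cells (Homo sapiens) for cytotoxicity, read by MTT assay, with a stated time of 72 h; a lower number here means a stronger inhibitor, a higher number a weaker inhibitor:
compound 1 `O=C(Nc1ccc(Oc2ccnc3[nH]ccc23)cc1)c1nn(-c2ccc(Cl)c(F)c2)ccc1=O`: 2580 nM
compound 2 `O=C(Nc1ccc(Oc2ccnc3[nH]ccc23)cc1)c1nn(-c2ccc(Cl)c(C(F)(F)F)c2)ccc1=O`: 2190 nM
compound 3 `Cn1ccc2c(Oc3ccc(NC(=O)c4nn(-c5ccc(Cl)c(F)c5)ccc4=O)cc3)ccnc21`: > 60000 nM (a limit of the assay, not a number)

Compound 1 and compound 2 share a core and differ only by trifluoromethyl in place of fluoro on an aromatic carbon; in this assay the step is a 1.2-fold lower number from compound 1 to compound 2 (0.07 log units; within the scatter). Compound 3 carries the same side group as compound 1 on a different core, the two cores differing by methyl in place of hydrogen on an aromatic nitrogen. The step is an at least 23-fold higher number from compound 1 to compound 3 (1.36 log units; beyond the scatter). For compound 3 the assay gives only a limit, (the limit of > 60000 nM in this assay, at which 1 of the 3 values shown sits), so the true size of that step is not known.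

Compound 4 `Cn1ccc2c(Oc3ccc(NC(=O)c4nn(-c5ccc(Cl)c(C(F)(F)F)c5)ccc4=O)cc3)ccnc21` has not been measured. It differs from compound 3 by trifluoromethyl in place of fluoro on an aromatic carbon, the same change as that from compound 1 to compound 2. Its expected effect in this assay is small, since the measured step of a 1.2-fold lower number from compound 1 to compound 2 (0.07 log units; within the scatter) is within the scatter, and the expected step is a step that the limit leaves unreadable from compound 3 to compound 4. Compound 4 is therefore expected to sit at the limit as compound 3 does, estimated at 80000 nM with a range of 40000 nM to 200000 nM.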

Compound 4, half-maximal inhibitory concentration: 11400 nM
Beside the measured number, compound 4's estimate is 7.0-fold (0.85 log units) above it; the whole stated range lies above it.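

In this assay, trifluoromethyl in place of fluoro gives an at least 5.2-fold lower number from compound 3 to compound 4 (0.72 log units; beyond the scatter) on the methylated core, so the size of this change does not carry over unchanged from the core of compound 1: the same change on two cores in this assay, a 1.2-fold lower number (0.07 log units; within the scatter) from compound 1 to compound 2 and an at least 5.2-fold lower number (0.72 log units; beyond the scatter) from compound 3 to compound 4, at least 4.4-fold (0.65 log units) apart, beyond the scatter of two such steps. Methyl in place of hydrogen on the aromatic nitrogen, read with trifluoromethyl in place, gives a 5.2-fold higher number from compound 2 to compound 4 (0.72 log units; beyond the scatter), and this step also differs from the one read with fluoro in place: the same change on two cores in this assay, an at least 23-fold higher number (1.36 log units; beyond the scatter) from compound 1 to compound 3 and a 5.2-fold higher number (0.72 log units; beyond the scatter) from compound 2 to compound 4, at least 4.4-fold (0.65 log units) apart, beyond the scatter of two such steps. Compound 3 gives > 60000 nM, a limit of the assay and not a number, so the comparison fixes neither the true size of either gap nor its cause, and it rests on a single pair of cores: the limit of > 60000 nM in this assay, at which 1 of the 4 values shown sits.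

Still open, from the compounds shown here alone, is whether the same dependence on the core appears when a nitrile or a methoxy group takes the place of fluoro. Also open, going by these compounds, is whether an ethyl group or a longer chain on the aromatic nitrogen behaves as methyl does.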